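Replacing the 5-methoxypyridin-2-yl Group of Compound 1

This account rests on a few compounds, and the source may have more. Where it says the series, first, only, none or still open, it means among the compounds named here.

Three compounds of this series have numbers in a physicochemical assay for lipophilicity, at pH 7.4; a lower number here means a more polar compound, a higher number a more lipophilic compound. Compound 1 `COc1ccc(NC(=O)[C@H]2CCCN2C(=O)C2(c3cccc(Cl)c3)CCCC2)nc1` gives 6.8, the highest of the three. Compound 3 `CNC(=O)c1cccc(NC(=O)[C@H]2CCCN2C(=O)C2(c3cccc(Cl)c3)CCCC2)c1` gives 5.5, and compound 2 `COc1ccc(C2(C(=O)N3CCC[C@@H]3C(=O)Nc3ccc4[nH]ncc4n3)CCC2)cc1` gives 3.9. Both lie lower than compound 1 by more than the scatter, with compound 3 the nearer of the two.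

The compound still to be measured, compound 4 `CNC(=O)c1ccc(NC(=O)[C@H]2CCCN2C(=O)C2(c3cccc(Cl)c3)CCCC2)cc1`, keeps the core of compound 1 and differs in one place: 4-(methylcarbamoyl)phenyl in place of 5-methoxypyridin-2-yl on an amide-type nitrogen. Among the measured compounds shown here, compound 2 differs from compound 1 in more than one place, so it offers no step for this change.

For the measured compounds named here, one measured step bears on it: a number 1.30 log units lower from compound 1 to compound 3 (beyond the scatter). There, 3-(methylcarbamoyl)phenyl takes the place of the same group on the same kind of nitrogen. Going by the values given here, that is a single step, and no measurement yet compares the 3-(methylcarbamoyl)phenyl and 4-(methylcarbamoyl)phenyl groups directly, so the range is kept wide. A large step of similar size and the same direction is therefore expected in this assay, an estimated a number 1.30 log units lower from compound 1 to compound 4 (beyond the scatter). The expected number for compound 4 is 5.5, within an estimated range from 4.9 to 6.1.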

Compound 4, distribution coefficient: 5.3
Beside the measured number, compound 4's estimate is 0.20 log units above it; the measured number falls inside the stated range.
By their numbers in this assay, from the lowest: compound 2; then compounds 4 and 3 (each within the scatter of the next); then compound 1.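

With the 4-(methylcarbamoyl)phenyl group on the amide-type nitrogen, this assay gives a large step, a number 1.50 log units lower from compound 1 to compound 4 (beyond the scatter), so the large fall seen with compound 3 is no longer a single case. Among the compounds shown here, the first direct comparison of the two methylcarbamoyl-bearing groups gives a number 0.20 log units lower from compound 3 to compound 4 (within the scatter), and on this evidence the 3-(methylcarbamoyl)phenyl and 4-(methylcarbamoyl)phenyl groups cannot be told apart in this assay. Nothing in the available data accounts for the size of the step from the 5-methoxypyridin-2-yl group to either of these groups.

Both steps away from compound 1 change the six-membered aromatic ring with its hetero atom to a ring of carbon only and, at the same time, exchange methoxy for methylcarbamoyl, so the compounds shown leave open how much of the fall belongs to each of these two changes; an unsubstituted phenyl or a 4-methoxyphenyl group on the same nitrogen would divide them. Also open, on these data alone, is how the number would respond if the methylcarbamoyl group gave way to a carboxylic acid or an amine on that ring.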